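Bromo for chloro on a shared core

A few compounds are considered here, and "the series" means these few. Any claim that something is new, unique, unknown or untested is made for them only; others in the source may bear on it.

- compound 1 `O=C1C(=Cc2ccc(O)cc2)C(=O)N(c2ccc(Cl)cc2)N1c1ccc(Cl)cc1`: 34200 nM
- compound 2 `O=C1C(=Cc2ccc(Cl)cc2)C(=O)N(c2ccc(Cl)cc2)N1c1ccc(Cl)cc1`: 17300 nM

In a functional assay on ECa-109 cells (Homo sapiens) for cytotoxicity, read by MTT assay, with a stated time of 72 h (a lower number here means a stronger inhibitor, a higher number a weaker inhibitor), compound 2 gives 17300 nM, and compound 1 gives 34200 nM. These two values lie within the scatter of each other, so compound 2 stands level with compound 1 and neither can be ranked.

Compound 3 `O=C1C(=Cc2ccc(Br)cc2)C(=O)N(c2ccc(Cl)cc2)N1c1ccc(Cl)cc1` has not yet been measured. It departs from compound 2 at a single place: bromo in place of chloro on an aromatic carbon. This is bromo in place of chloro on an aromatic carbon, para to a large group, so that 4-chlorophenyl becomes 4-bromophenyl.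

Within the data shown here, only one measured step bears on this change. It is a 2.0-fold lower number from compound 1 to compound 2 (0.30 log units; within the scatter), with chloro in place of hydroxy on an aromatic carbon, and it stays within the scatter. Among the measured compounds shown here, no measured pair exchanges chloro for bromo, so the evidence is thin. With that one step so small, no shift beyond the scatter is expected in this assay, and no direction can be argued. The estimate therefore stays close to compound 2 at 17300 nM, and it means an expected 1.1-fold lower number from compound 2 to compound 3 (0.03 log units; within the scatter).

For compound 3 the estimated value is 16000 nM, with an expected range of 7000 nM to 38000 nM.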

Compound 3, half-maximal inhibitory concentration: 12300 nM
For compound 3 the middle estimate is 1.3-fold (0.11 log units) above the measured one; the measured number falls inside the stated range.
By their numbers in this assay, from the lowest: compounds 3, 2 and 1 (each within the scatter of the next, the first and the last beyond it).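

In this assay, the direct exchange of chloro for bromo on an aromatic carbon, para to a large group, gives a 1.4-fold lower number from compound 2 to compound 3 (0.15 log units; within the scatter), so these two groups stand level at this position. The comparison with hydroxy now yields its first separation: bromo in place of hydroxy gives a 2.8-fold lower number from compound 1 to compound 3 (0.44 log units; beyond the scatter), whereas the matching step with chloro, a 2.0-fold lower number from compound 1 to compound 2 (0.30 log units; within the scatter), does not pass the scatter. Compound 2 therefore remains level with both compound 1 and compound 3, so the three values form a chain rather than a clean order of groups, and the one modest separation holds only for bromo against hydroxy.

No accompanying measurement bears on what lies behind these numbers. The compounds shown leave open how an amine, a methoxy group or a nitrile at this position would read in this assay, and whether a change elsewhere on the shared core would move the values further than any exchange seen here.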